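This account rests on a few compounds, and the source may have more. Where it says the series, first, only, none or still open, it means among the compounds named here.

In a functional assay on HL-60 cells (Homo sapiens) for inhibition, read by CCK-8 assay, with a stated time of 48 h (on this read-out higher numbers stand for weaker inhibition and lower numbers for stronger inhibition), compound 1 (`O=S(=O)(NCCNC(=S)Nc1cccc(Cl)c1)c1ccc(-c2ccccc2OCc2cccc(O)c2)s1`) gives 1800 nM. Compound 2 (`COc1ccc(NC(=O)NCCNS(=O)(=O)c2ccc(-c3ccccc3Oc3ccc([N+](=O)[O-])cc3)s2)cc1`) stands at > 50000 nM, and this reading is a limit of the assay and not a number. Compound 3 (`O=[N+]([O-])c1ccc(Oc2ccccc2-c2ccc(S(=O)(=O)NCCNC(=S)Nc3cccc(Cl)c3)s2)cc1`) departs from compound 2 in one place, on an amine nitrogen whose other neighbours are a saturated chain carbon: a group of 10 heavy atoms (7 carbon, 1 nitrogen, 1 sulfur, 1 chlorine; one six-membered aromatic ring of carbon only) in place of a group of 11 heavy atoms (8 carbon, 1 nitrogen, 2 oxygen; one six-membered aromatic ring of carbon only), on an amine nitrogen. The (4-methoxyphenyl)carbamoyl group leaves there. In this assay a step towards stronger inhibition, beyond the usual scatter, is expected because compound 1 with the same entering group gives 1800 nM. Among the measured compounds shown here, no measurement yet shows that group together with the rest of compound 2, so the expectation stays wide. The estimated step is an at least 16-fold lower number from compound 2 to compound 3 (1.22 log units; beyond the scatter). Compound 3 is expected at about 3000 nM, with an estimated range of 800 nM to 15000 nM.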

Compound 3, half-maximal inhibitory concentration: > 50000 nM
Compound 3 gave a limit, no number; the forecaster's own chance of this, stated with the estimate: 15%; middle value at least 16-fold (1.22 log units) away from the limit.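

With the group on the amine nitrogen the same in both compounds, 4-nitrophenyl in place of 3-hydroxybenzyl on an oxygen on an aromatic ring brings an at least 27-fold higher number from compound 1 to compound 3 (1.44 log units; beyond the scatter), a lower bound set by a limit of the assay. The group that entered on the amine nitrogen therefore does not by itself carry the inhibition seen for compound 1 in this assay; compound 3 shows that it also depends on the group on that oxygen. The step between compound 2 and compound 3 cannot be read because both compounds stand at a limit: the limit of > 50000 nM in this assay, at which 2 of the 3 values shown sit.

On these data alone, whether either group on the amine nitrogen makes any difference with 4-nitrophenyl in place remains open. As far as these compounds go, it also remains open how a plain benzyl or a 3-aminobenzyl on that oxygen would compare with 3-hydroxybenzyl.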